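The source may hold more compounds than are shown below. What is called first, only, known or untested is meant among the compounds shown, and "the series" means these compounds.

Measured in a functional assay on HCT-116 cells (Homo sapiens) for inhibition, read by MTT assay, with a stated time of 48 h; a higher number here means a weaker inhibitor, a lower number a stronger inhibitor:
- compound 1 `COc1ccc(CN(C(C)=O)c2cc(OC)c(OC)c(OC)c2)cc1O`: 270 nM
- compound 2 `COc1cc(NCc2ccc(Cl)cc2)cc(OC)c1OC`: > 80000 nM (a limit)
- compound 3 `C#CC(=O)N(Cc1ccc(OC)c(O)c1)c1cc(OC)c(OC)c(OC)c1`: 310 nM

Compound 2 stands at the limit of > 80000 nM in this assay, at which 1 of the 3 values shown sits: its > 80000 nM is a limit of the assay and not a number. The next compound, compound 4 `COc1ccc(CNc2cc(OC)c(OC)c(OC)c2)cc1`, has methoxy in place of chloro on an aromatic carbon, para to a large group: methoxy in place of chloro on an aromatic carbon.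

Among the measured compounds shown here, no measured step covers this change. For the measured compounds named here, the only one, a 1.1-fold higher number from compound 1 to compound 3 (0.06 log units; within the scatter), replaces methyl with ethynyl on a carbonyl carbon, elsewhere in the molecule, and stays within the scatter, so it gives no size for this step. The expectation therefore rests mainly on compound 2 and its limit of > 80000 nM. Compound 4 is expected to stay weak in this assay, near that limit or modestly stronger.

The estimated value for compound 4 is 40000 nM, with an expected range from 8000 nM to 120000 nM. This estimate means an expected at least 2.0-fold lower number from compound 2 to compound 4 (0.30 log units; that floor lies within the scatter).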

Compound 4, half-maximal inhibitory concentration: 18400 nM
Compound 4: the middle estimate sits 2.2-fold (0.34 log units) above what was measured; the range from low to high includes it.
By their numbers in this assay, from the lowest: compounds 1 and 3 (each within the scatter of the next); then compound 4. At a limit, above all of these: compound 2.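

In this assay, methoxy in place of chloro on an aromatic carbon, para to a large group, gives an at least 4.3-fold lower number from compound 2 to compound 4 (0.63 log units; beyond the scatter), which lies beyond the scatter. Among the compounds shown here, this is the first measured step at this position, and it shows that the number in this assay responds to the group placed there, whereas the one earlier step concerned a different part of the molecule. Compound 2 stands at a limit and not a number, so the step gives only a floor for the true size of the change: the limit of > 80000 nM in this assay, at which 1 of the 4 values shown sits.

The compounds shown leave open how other groups at this position, such as a hydroxyl, an amine or an ethoxy, would read. They also leave open whether this change would give a step of similar size with the amide nitrogen of compound 1 in place.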